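Trimming the benzyl arm of compound 3 to propyl

A few compounds are considered here, and "the series" means these few. Any claim that something is new, unique, unknown or untested is made for them only; others in the source may bear on it.

Three compounds have so far been measured in a functional assay on HT-29 cells (Homo sapiens) for inhibition, read by MTT assay, with a stated time of 2 days; on this read-out lower numbers stand for stronger inhibition of growth and higher numbers for weaker inhibition of growth:

compound 1 `O=C(Nn1c(-c2cccc([N+](=O)[O-])c2)nc2c(-c3ccc(Cl)cc3)n[nH]c2c1=O)c1ccccc1` gives 18500 nM
compound 2 `O=C(Nn1c(-c2ccccc2)nc2c(-c3ccc(Cl)cc3)n[nH]c2c1=O)c1ccccc1` gives 20600 nM
compound 3 `COc1cccc(Cc2nc3c(-c4ccc(Cl)cc4)n[nH]c3c(=O)n2NC(=O)c2ccccc2)c1` gives 22100 nM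

Compound 3 holds the highest of the three numbers, but only by margins that mean nothing: a 1.2-fold higher number from compound 1 to compound 3 (0.08 log units; within the scatter) and a 1.1-fold higher number from compound 2 to compound 3 (0.03 log units; within the scatter) are both within the scatter, as is a 1.1-fold higher number from compound 1 to compound 2 (0.05 log units; within the scatter). Compound 4 `CCCc1nc2c(-c3ccc(Cl)cc3)n[nH]c2c(=O)n1NC(=O)c1ccccc1` has not been measured. It differs from compound 3 by ethyl in place of 3-methoxyphenyl on a saturated chain carbon bound to an aromatic carbon. For the measured compounds named here, the two measured steps that end at compound 3 both swapped one group for another on that same aromatic carbon of the shared core and left the numbers within the scatter; compound 4 goes further and takes the aromatic ring away entirely, a change no measured step covers. Since every substituent tried at that place has so far been indifferent, compound 4 is expected to sit close to compound 3, with the step of a 1.1-fold higher number from compound 3 to compound 4 (0.05 log units; within the scatter) expected to stay within the scatter. In this assay compound 4 is estimated at 25000 nM, with a range from 10000 nM to 60000 nM.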

Compound 4, concentration for 50% growth inhibition: 9260 nM
Compound 4: middle estimate off by 2.7-fold (0.43 log units), on the high side; the measured number lies below the stated range.
By their numbers in this assay, from the lowest: compounds 4, 1, 2 and 3 (each within the scatter of the next, the first and the last beyond it).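

In this assay, this place on the shared core had shown no response among compounds 1, 2 and 3, but it now separates propyl from two of the three larger groups: the change from 3-methoxybenzyl to propyl gives a modest step (a 2.4-fold lower number from compound 3 to compound 4 (0.38 log units; beyond the scatter)), and propyl in place of phenyl gives another (a 2.2-fold lower number from compound 2 to compound 4 (0.35 log units; beyond the scatter)). Compound 1 goes against this pattern, as propyl in place of 3-nitrophenyl stays within the scatter (a 2.0-fold lower number from compound 1 to compound 4 (0.30 log units; within the scatter)). Nothing available accounts for the difference between these steps.

As far as these compounds go, whether this belongs to propyl itself or to saturated chains in general remains open. A shorter chain such as methyl, a longer one such as pentyl, or a cyclohexyl ring at the same place would separate chain length from the loss of the aromatic ring.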